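The compounds below may be only part of what the source reports. "The series", "measured", "known", "first", "only" and "open" are said of these compounds alone.

Measured in a functional assay on A2780 cells (Homo sapiens) for inhibition, read by sulforhodamine B assay; on this read-out higher numbers stand for weaker inhibition of growth and lower numbers for stronger inhibition of growth:
- compound 1 `Clc1cccc(-c2ccc(-c3ccc(-c4nc5ccccc5[nH]4)cc3)cc2)c1` gives 31100 nM
- compound 2 `Oc1cccc2[nH]c(-c3ccc(-c4ccc(-c5ccccc5)cc4)cc3)nc12` gives 41000 nM
- compound 3 `CN(C)c1ccc(-c2ccc(-c3ccc(-c4nc5c(O)cccc5[nH]4)cc3)cc2)cc1` gives 3010 nM

Compound 3 has the lowest number of the three, with gaps to both others beyond the scatter. Compound 1 and compound 2 lie within the scatter of each other.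

Next is compound 4 `Oc1cccc2[nH]c(-c3ccc(-c4ccc(-c5cccc(Cl)c5)cc4)cc3)nc12`, with 3-chlorophenyl in place of 4-(dimethylamino)phenyl on an aromatic carbon. Within the data shown here, one measured step bears directly on this: adding dimethylamino in place of hydrogen gave a large drop (a 14-fold lower number from compound 2 to compound 3 (1.13 log units; beyond the scatter)). Compound 4 lacks that group, so a rise of similar size is expected. Compound 1 carries the same 3-chlorophenyl group on a core without the hydroxyl and gives 31100 nM as a second reference. Among the measured compounds shown here, no measured step isolates the chlorine on the hydroxylated core, so the range stays wide.

The step expected is large and upward (a 9.3-fold higher number from compound 3 to compound 4 (0.97 log units; beyond the scatter)). Compound 4 is estimated at 28000 nM (expected range 10000 nM to 60000 nM).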

Compound 4, concentration for 50% growth inhibition: 2800 nM
Compound 4: the middle estimate sits 10-fold (1.00 log units) above what was measured, and the stated range ends above it.
By their numbers in this assay, from the lowest: compounds 4 and 3 (each within the scatter of the next); then compounds 1 and 2 (each within the scatter of the next).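

Read in this assay, the exchange of 4-(dimethylamino)phenyl for 3-chlorophenyl at this position leaves the number within the scatter (a 1.1-fold lower number from compound 3 to compound 4 (0.03 log units; within the scatter)), so among the compounds shown the dimethylamino group is not the only substituent here that goes with a low number. Chloro in place of hydrogen on an aromatic carbon gives a large step of its own (a 15-fold lower number from compound 2 to compound 4 (1.17 log units; beyond the scatter)), and with 3-chlorophenyl held fixed, hydroxy in place of hydrogen on the core gives another (an 11-fold lower number from compound 1 to compound 4 (1.05 log units; beyond the scatter)). No measurement at hand explains why either change acts as it does.

Open, on these data alone, is whether the hydroxy step holds with 4-(dimethylamino)phenyl in place of 3-chlorophenyl. Also open, as far as these compounds go, is whether a methoxy group or a carboxylic acid in place of the chloro keeps the number this low.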